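This account rests on a few compounds, and the source may have more. Where it says the series, first, only, none or still open, it means among the compounds named here.

In a physicochemical assay for lipophilicity (on this read-out lower numbers stand for lower lipophilicity and higher numbers for higher lipophilicity), compound 1 `Cc1nsc(N2C[C@H]3CC[C@@H](C2)C3NC2=NC3C=CC=C(c4ccc(F)c(F)c4F)C3=N2)n1` gives 4.4 and compound 2 `Cc1nsc(N2C[C@H]3CC[C@@H](C2)C3NC2=NC3C=CC=C(OC(F)(F)F)C3=N2)n1` gives 3.17. Compound 3 `CC(C)c1nc(N2CCN(c3ncc(OCc4ccncc4C#N)cn3)CC2)no1`, from a different structural family, gives 3.3. Among the compounds with values here, that number lies within the scatter of the one for compound 2 and beyond the scatter under the one for compound 1.

Compound 4 `Cc1nc(N2CCN(c3ncc(OCc4ccncc4C#N)cn3)CC2)no1` has not yet been measured. It differs from compound 3 in one place, (methyl in place of isopropyl on an aromatic carbon). Put another way, 5-isopropyl-1,2,4-oxadiazol-3-yl becomes 5-methyl-1,2,4-oxadiazol-3-yl.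

Within the data shown here, only one measured step is available for comparison, a number 1.23 log units lower from compound 1 to compound 2 (beyond the scatter). It is large, but it is a different exchange on a different core, so it shows only that a single replacement can move this read-out well beyond the scatter. Among the measured compounds shown here, no measured pair makes the exchange of isopropyl for methyl itself. For the measured compounds named here, since carbon leaves and no hydrogen-bond donor, acceptor or charge enters, a fall is expected, smaller than the one seen in that step but still beyond the scatter.

The expected change is a number 0.70 log units lower from compound 3 to compound 4 (beyond the scatter). For compound 4 the estimated value is 2.6, with an expected range from 2.2 to 3.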

Compound 4, distribution coefficient: 4
The estimate for compound 4 lay 1.40 log units below the measured number; the whole stated range lies below it.
By their numbers in this assay, from the lowest: compounds 2 and 3 (each within the scatter of the next); then compound 4; then compound 1.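

In this assay, the exchange of isopropyl for methyl on this aromatic carbon, the one next to the ring nitrogen and next to the ring oxygen of the five-membered aromatic ring, gives a number 0.70 log units higher from compound 3 to compound 4 (beyond the scatter). Within the data shown here, this is the first measured reading at this position, and it shows that here the number went up when the substituent shrank from 3 heavy atoms to 1, with no hydrogen-bond donor, acceptor or net charge entering or leaving, so removing carbon at this place did not bring the read-out down in this pair. Nothing measured among these compounds accounts for the direction of this step.

A single pair cannot show whether the same exchange would move the number the same way on another core, such as that of compound 1, or with other groups elsewhere on the shared core of compound 3 and compound 4. Also open, going by these compounds, is whether ethyl on this aromatic carbon would give a number between those of methyl and isopropyl, and where an amine or a carboxylic acid at the same place would put the read-out.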